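Extending a Methyl Group on a Weak Cell Inhibitor

The source may report more compounds than this note shows. Statements on the series, on what has been measured and on what is new or still open speak of the compounds shown alone.

Among the measured compounds shown here, compound 2 `Cc1cccc2[nH]c(-c3n[nH]c4ncc(-c5cncc6ccccc56)cc34)nc12` gives 3090 nM in a functional assay on HeLa cells (Homo sapiens) for antiproliferative activity (a higher number here means a weaker inhibitor, a lower number a stronger inhibitor), and carries the higher of the two numbers measured so far; compound 1 `c1ccc2c(-c3cnc4[nH]nc(-c5nc6ccccc6[nH]5)c4c3)cncc2c1` gives 1700 nM, and the step of a 1.8-fold higher number from compound 1 to compound 2 (0.26 log units; within the scatter) lies within the scatter. Compound 3 `CC(C)OCc1cccc2[nH]c(-c3n[nH]c4ncc(-c5cncc6ccccc56)cc34)nc12` differs from compound 2 by isopropoxy in place of hydrogen on a saturated chain carbon bound to an aromatic carbon. For the measured compounds named here, the only step available, which put a methyl in place of hydrogen, showed no change beyond the scatter, so for compound 3 a step of a 1.0-fold lower number from compound 2 to compound 3 (0.01 log units; within the scatter) is expected, essentially none beyond the scatter. Compound 3 is therefore estimated to give 3000 nM in this assay, within 1000 nM to 9000 nM.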

Compound 3, half-maximal inhibitory concentration: 2400 nM
Estimate against measurement, compound 3: 1.3-fold (0.10 log units) above; the range from low to high includes it.
By their numbers in this assay, from the lowest: compounds 1, 3 and 2 (each within the scatter of the next).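

Isopropoxymethyl, where the earlier compounds carried only methyl or hydrogen on an aromatic carbon, keeps the number in this assay within the scatter of both (a 1.3-fold lower number from compound 2 to compound 3 (0.11 log units; within the scatter)) and (a 1.4-fold higher number from compound 1 to compound 3 (0.15 log units; within the scatter)). This place therefore accepts a larger group than methyl without a change beyond the scatter, but the larger group brings no gain in potency either.

No available measurement explains this flat response. As far as these compounds go, whether an amine or a carboxylic acid on that saturated chain carbon would move the number beyond the scatter remains open.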